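Taking the phenyl off compound 1

This account rests on a few compounds, and the source may have more. Where it says the series, first, only, none or still open, it means among the compounds named here.

In a functional assay on MDA-MB-435 cells (Homo sapiens) for antiproliferative activity, read by sulforhodamine B assay, with a stated time of 72 h (on this read-out lower numbers stand for stronger inhibition and higher numbers for weaker inhibition), compound 1 `O=C1CS/C(=N/Nc2nncc3ccccc23)N1c1ccccc1` gives 44 nM and compound 2 `COc1ccc(NC(=S)NNc2nncc3ccccc23)cc1` gives 88 nM as its reading, so the two stand level within the usual scatter. For the measured compounds named here, compound 1 therefore sits alongside the only other compound measured so far.

The next compound, compound 3 `O=C1CS/C(=N/Nc2nncc3ccccc23)N1`, keeps the core of compound 1 and changes one place: hydrogen in place of phenyl on an amide-type nitrogen in a ring. Going by the values given here, the two measured compounds differ in more than one place, so no measured step shows what this swap does. With compound 1 at 44 nM as the starting point, losing a whole phenyl group is expected to move the number up in this assay and so weaken inhibition. The expected step is an 8.0-fold higher number from compound 1 to compound 3 (0.90 log units; beyond the scatter) and would lie beyond the scatter. The estimate for compound 3 is 350 nM (from 80 nM to 2000 nM).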

Compound 3, half-maximal inhibitory concentration: 56 nM
For compound 3 the middle estimate is 6.3-fold (0.80 log units) above the measured one; measured number below the stated range.
By their numbers in this assay, from the lowest: compounds 1, 3 and 2 (each within the scatter of the next).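

Putting hydrogen in place of phenyl on the amide-type nitrogen in the ring gives a 1.3-fold higher number from compound 1 to compound 3 (0.10 log units; within the scatter) in this assay, so the two compounds stand level. Before this pair, nothing showed what the phenyl contributes at this position. Here, an entire six-membered aromatic ring can go and the reading stays within the scatter, so in this pair the phenyl is not needed to keep the reading in this range, and the data at hand offer no explanation for this.

Phenyl and hydrogen are the only two groups shown on this nitrogen, so they mark out very little of what the position accepts. A methyl group, a longer chain or a chain ending in a carboxylic acid could hold the reading level or shift it, and the compounds shown cannot tell which.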